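The compounds below may be only part of what the source reports. "The series", "measured", "known", "first", "only" and "open" are said of these compounds alone.

In a functional assay (Saphenous vein) for inhibition, with Oryctolagus cuniculus as the target (a lower number here means tighter binding, a higher number weaker binding), compound 1 `O=C(O)CCc1cc(-c2cccnc2)cc2c1CCC(NS(=O)(=O)c1ccc(Cl)cc1)C2` gives 12.6 nM, compound 2 `O=C(O)CCc1cc(Cc2cccnc2)cc2c1CCC(NS(=O)(=O)c1ccc(Cl)cc1)C2` gives 0.2 nM and compound 3 `Cc1c(Cc2cccnc2)cc2c(c1CCC(=O)O)CCC(NS(=O)(=O)c1ccc(Cl)cc1)C2` gives 158 nM, the highest of the three numbers. Two large steps frame this series: a 63-fold lower number from compound 1 to compound 2 (1.80 log units; beyond the scatter) with (pyridin-3-yl)methyl in place of pyridin-3-yl on an aromatic carbon, and a 790-fold higher number from compound 2 to compound 3 (2.90 log units; beyond the scatter) with methyl in place of hydrogen on an aromatic carbon. Compound 4 `O=C(O)CCc1c2c(cc(Cc3cccnc3)c1-c1ccccc1)CC(NS(=O)(=O)c1ccc(Cl)cc1)CC2` carries phenyl in place of methyl on an aromatic carbon. For the measured compounds named here, no measured compound carries phenyl there, so only a 790-fold higher number from compound 2 to compound 3 (2.90 log units; beyond the scatter) bears on this position, and it points upward. A further, much smaller rise is therefore expected, with wide uncertainty. The estimated step is a 2.5-fold higher number from compound 3 to compound 4 (0.40 log units; beyond the scatter). For compound 4 the expected value is 400 nM, within an estimated range of 40 nM to 4000 nM.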

Compound 4, dissociation constant: 0.794 nM
The estimate for compound 4 lay 500-fold (2.70 log units) above the measured number; measured number outside the range, below it.
By their numbers in this assay, from the lowest: compound 2; then compound 4; then compound 1; then compound 3.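

In this assay, the rise seen with methyl on this aromatic carbon, ortho to the (pyridin-3-yl)methyl and 2-carboxyethyl groups, does not hold for every group placed there: phenyl in place of methyl gives a 200-fold lower number from compound 3 to compound 4 (2.30 log units; beyond the scatter). Set against hydrogen, phenyl leaves only a 4.0-fold higher number from compound 2 to compound 4 (0.60 log units; beyond the scatter), a modest step, so a much larger group is nearly matched to hydrogen while methyl is not. Nothing available explains this reversal. On these data alone, whether an ethyl group, a methoxy group or a pyridine ring there would follow methyl or phenyl remains open, as does how phenyl would behave with pyridin-3-yl in place of (pyridin-3-yl)methyl.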